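Compound 3 to compound 4: pyrimidin-2-yl for 3-fluorophenyl

The source may hold more compounds than are shown below. What is called first, only, known or untested is meant among the compounds shown, and "the series" means these compounds.

Three compounds have numbers in a functional assay on A2780 cells (Homo sapiens) for antiproliferative activity, read by CellTiter-Glo, with a stated time of 72 h; a lower number here means a stronger inhibitor, a higher number a weaker inhibitor. Compound 1 (`C[C@H](NC(=O)c1ncccn1)c1ccc(NC(=O)N2CC(c3cccnc3)C2)cc1`) gives 36 nM, compound 2 (`C[C@@H](c1ccc(NC(=O)N2CC(c3ccc(N)nc3)C2)cc1)N1Cc2ccccc2C1=O`) gives 5.9 nM, and compound 3 (`C[C@H](NC(=O)c1cccc(F)c1)c1ccc(NC(=O)N2CC(c3ccc(N)nc3)C2)cc1`) gives 7.6 nM. Compound 3 therefore lies within the scatter of compound 2, while the number for compound 1 is higher than both, by a gap beyond the scatter.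

The next structure is compound 4 (`C[C@H](NC(=O)c1ncccn1)c1ccc(NC(=O)N2CC(c3ccc(N)nc3)C2)cc1`), with pyrimidin-2-yl in place of 3-fluorophenyl on a carbonyl carbon.

Among the compounds with values here, the only measured step is a 1.3-fold higher number from compound 2 to compound 3 (0.11 log units; within the scatter). It exchanged a whole group on a saturated chain carbon and stayed within the scatter, but it does not test this change directly. Compound 1 carries the same pyrimidin-2-yl on a carbonyl carbon and gives 36 nM. It also differs from compound 3 elsewhere in the structure, so that gap cannot be assigned to this change alone. It does leave room for some upward movement.

The expected step is a 1.2-fold higher number from compound 3 to compound 4 (0.07 log units; within the scatter), with no change beyond the scatter anticipated and any drift more likely upward. The estimate for compound 4 is 9 nM, with an expected range of 3 nM to 25 nM.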

Compound 4, half-maximal inhibitory concentration in the A2780 assay: 68 nM
Compound 4: middle estimate off by 7.6-fold (0.88 log units), on the low side, and the stated range ends below it.
By their numbers in the A2780 assay, from the lowest: compounds 2 and 3 (each within the scatter of the next); then compounds 1 and 4 (each within the scatter of the next).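

This position is not a neutral place for exchange: in the A2780 assay, pyrimidin-2-yl in place of 3-fluorophenyl on a carbonyl carbon gives an 8.9-fold higher number from compound 3 to compound 4 (0.95 log units; beyond the scatter), whereas the earlier exchange of a whole group on the saturated chain carbon gave a 1.3-fold higher number from compound 2 to compound 3 (0.11 log units; within the scatter). With pyrimidin-2-yl in the amide, the A2780 assay shows a 12-fold higher number from compound 2 to compound 4 (1.06 log units; beyond the scatter), while amino in place of hydrogen on an aromatic carbon gives only a 1.9-fold higher number from compound 1 to compound 4 (0.28 log units; within the scatter), so with this group present the amino change stays within the scatter. In a physicochemical assay for solubility, read by LC-MS, in phosphate buffer, with a stated time of 24 h, at pH 6.8 (on this read-out higher numbers stand for higher solubility and lower numbers for lower solubility), compound 3 gives 32000 nM and compound 4 gives 300000 nM. The same exchange that weakens compound 4 also comes with a gain in the physicochemical assay: the measured solubility of compound 3, 32000 nM, and of compound 4, 300000 nM, a 9.4-fold higher number (0.97 log units; beyond the scatter)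

On these data alone, whether pyridin-2-yl on the same carbonyl carbon, with one ring nitrogen in place of two, would keep compound 3 near 7.6 nM in the A2780 assay while retaining part of the solubility of compound 4 stays open. The exchange of 3-fluorophenyl for pyrimidin-2-yl is also read on a single background, the core of compound 3, so how far it carries to other groups on the saturated chain carbon remains unsettled.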